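Swapping trifluoromethyl for bromo on the triazole-linked phenyl

This account rests on a few compounds, and the source may have more. Where it says the series, first, only, none or still open, it means among the compounds named here.

Measured so far:
- Compound 1 `C=C1C(=O)[C@]23C[C@@]1(O)CC[C@H]2c1ccc(OS(=O)(=O)c2ccc(C)cc2)c(C)c1[C@@H]3Cn1cc(-c2ccc(Br)cc2)nn1`: 1590 nM
- Compound 2 `C=C1C(=O)[C@]23C[C@@]1(O)CC[C@H]2c1ccc(O)c(C)c1[C@@H]3Cn1cc(-c2ccc(C(F)(F)F)cc2)nn1`: 370 nM

Both compounds share a rigid polycyclic core carrying a triazole that bears a substituted phenyl ring. In a functional assay on SW480 cells (Homo sapiens) for cytotoxicity, read by MTT assay, with a stated time of 4 days (a lower number here means a stronger inhibitor, a higher number a weaker inhibitor), compound 1 gives 1590 nM, while compound 2 gives 370 nM. Compound 2 thus stands at the lowest number of the two, and the gap to compound 1 lies beyond the usual scatter. These two compounds differ in more than one place, so the gap between them cannot be tied to a single change.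

Compound 3 `C=C1C(=O)[C@]23C[C@@]1(O)CC[C@H]2c1ccc(O)c(C)c1[C@@H]3Cn1cc(-c2ccc(Br)cc2)nn1` keeps the free phenol of compound 2 and changes only the phenyl substituent: bromo in place of trifluoromethyl on an aromatic carbon. Among the measured compounds shown here, no measured pair isolates this swap. Both groups are small, uncharged and carry no hydrogen-bond donors or acceptors, so the step in this assay from compound 2 is expected to be modest, most likely a slight weakening that may not exceed the scatter. On that basis compound 3 is estimated at 550 nM, with a plausible range from 200 nM to 1500 nM, a step of a 1.5-fold higher number from compound 2 to compound 3 (0.17 log units; within the scatter).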

Compound 3, half-maximal inhibitory concentration: 310 nM
The estimate for compound 3 lay 1.8-fold (0.25 log units) above the measured number, and the stated range covers the measured number.
By their numbers in this assay, from the lowest: compounds 3 and 2 (each within the scatter of the next); then compound 1.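

In this assay, bromo in place of trifluoromethyl on the aromatic carbon of the triazole-linked phenyl ring gives a 1.2-fold lower number from compound 2 to compound 3 (0.08 log units; within the scatter), so at this position the assay does not tell the two groups apart, even though bromo is a single atom and trifluoromethyl has four heavy atoms. Compound 3 also supplies a comparison that the first two compounds could not give: with the 4-bromophenyl group held fixed, hydrogen in place of (4-methylphenyl)sulfonyl on the oxygen on the aromatic ring gives a 5.1-fold lower number from compound 1 to compound 3 (0.71 log units; beyond the scatter), a change that can now be read on its own and that, unlike the phenyl swap, lies beyond the scatter. Nothing available here explains either step.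

The compounds shown leave open whether the phenyl position tolerates only uncharged groups like these two, since an amine or a carboxylic acid there could behave quite differently. On these data alone, it is also open whether the oxygen needs its hydrogen or merely works without the large sulfonyl group, a question that a small methyl or acetyl group on that oxygen would address.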